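This account rests on a few compounds, and the source may have more. Where it says the series, first, only, none or still open, it means among the compounds named here.

Compound 2 `COc1cccc(-c2cc(C)c3ncc(CSCCc4ccccc4)n3c2)c1` gives 36 ug/mL in an ADME assay on HEL cells (Homo sapiens) for cytotoxicity, with a stated time of 3 days; a lower number here means that less compound is tolerated, a higher number that more compound is tolerated. Compound 1 `Cc1cc(-c2ccccc2)c2ncc(CSCCc3ccccc3)n2c1` gives 33 ug/mL in this assay, and the gap between these two numbers lies within the scatter, so they stand together. Compound 3 `Cc1cc(-c2cccs2)c2ncc(CSCCc3ccccc3)n2c1` gives only a limit of the assay in this assay, > 50 ug/mL, and no number. Among the compounds with values here, the one measured step on this part of the core, an at least 1.5-fold higher number from compound 1 to compound 3 (0.18 log units; that floor lies within the scatter), rests on that limit, (the limit of > 50 ug/mL in this assay, at which 1 of the 3 values shown sits), and its floor lies within the scatter, so no step beyond the scatter has been seen here.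

Compound 4 `Cc1cc(-c2ccc(C#N)cc2)cn2c(CSCCc3ccccc3)cnc12` differs from compound 2 in one place: 4-cyanophenyl in place of 3-methoxyphenyl on an aromatic carbon. Within the data shown here, no measured step exchanges one substituted phenyl for another at this carbon, so the expectation for compound 4 rests on the two numbers in hand and on the small measured step. The step expected from compound 2 to compound 4 is therefore none beyond the scatter, a 1.0-fold lower number from compound 2 to compound 4 (0.01 log units; within the scatter). Compound 4 is estimated at 35 ug/mL in this assay, with a range from 18 ug/mL to 50 ug/mL, and a limit of the assay rather than a number remains possible.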

Compound 4, half-maximal cytotoxic concentration: 10.6 ug/mL
Estimate against measurement, compound 4: 3.3-fold (0.52 log units) above; the measured number lies below the stated range.
By their numbers in this assay, from the lowest: compound 4; then compounds 1 and 2 (each within the scatter of the next). At a limit, above all of these: compound 3.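

Within the data shown here, at this aromatic carbon, meta to a methyl group, the choice of substituted phenyl matters in this assay: the change gives a 3.4-fold lower number from compound 2 to compound 4 (0.53 log units; beyond the scatter), the first step beyond the scatter. Both groups hold 8 heavy atoms, one hydrogen-bond acceptor and one six-membered aromatic ring of carbon only, so these counts alone do not set the number here. Among these compounds, nothing measured so far accounts for the step.

The pair does not separate the nitrile from its place on the phenyl ring, as the group and its place on that ring change together. Still open, on these data alone, is where a 3-cyanophenyl, a 4-methoxyphenyl or an aminophenyl on this carbon would stand in this assay.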